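Halogen swap at the distal phenyl ring

The source may report more compounds than this note shows. Statements on the series, on what has been measured and on what is new or still open speak of the compounds shown alone.

Within the data shown here, compound 3 `O=C(Nc1ccc(Oc2ccnc3[nH]ccc23)c(F)c1)c1ccc(-c2ccc(F)cc2)cn1` sits at the high end of the three numbers so far, with 6010 nM in a functional assay on A549 cells (Homo sapiens) for cytotoxicity, read by MTT assay, with a stated time of 72 h; on this read-out lower numbers stand for stronger inhibition and higher numbers for weaker inhibition; compound 1 `O=C(Nc1ccc(Oc2ccnc3[nH]ccc23)c(F)c1)c1ccc(-c2ccccc2)cn1` gives 1250 nM and compound 2 `Cc1ccc(-c2ccc(C(=O)Nc3ccc(Oc4ccnc5[nH]ccc45)c(F)c3)nc2)cc1` gives 2300 nM in this assay. Compound 4 `O=C(Nc1ccc(Oc2ccnc3[nH]ccc23)c(F)c1)c1ccc(-c2ccc(Cl)cc2)cn1` carries the change (chloro in place of fluoro on an aromatic carbon). Among the measured compounds shown here, no measured step covers a fluoro-to-chloro exchange. The steps that touch the same carbon are a 4.8-fold higher number from compound 1 to compound 3 (0.68 log units; beyond the scatter), a 1.8-fold higher number from compound 1 to compound 2 (0.26 log units; within the scatter) and a 2.6-fold higher number from compound 2 to compound 3 (0.42 log units; beyond the scatter): fluoro at this carbon sits at the weak end, while methyl sits close to hydrogen. Chloro resembles neither case in the data at hand, so the direction is open; the nearest guide is that a substituent other than fluoro at this carbon has given a lower number than fluoro, as compound 2 shows against compound 3. A step no larger than modest is therefore expected, most likely toward a lower number. For compound 4 the expected shift is a 1.5-fold lower number from compound 3 to compound 4 (0.18 log units; within the scatter). Compound 4 is accordingly estimated at 4000 nM, within 1500 nM to 12000 nM.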

Compound 4, half-maximal inhibitory concentration: 10000 nM
Compound 4: the middle estimate sits 2.5-fold (0.40 log units) below what was measured, and the stated range covers the measured number.
By their numbers in this assay, from the lowest: compounds 1 and 2 (each within the scatter of the next); then compounds 3 and 4 (each within the scatter of the next).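

In this assay the exchange of 4-fluorophenyl for 4-chlorophenyl gives a 1.7-fold higher number from compound 3 to compound 4 (0.22 log units; within the scatter) and so does not separate the two halogens at this carbon, which means that a substituent other than fluoro does not always give a lower number here. Chloro stands with fluoro at the weak end, with a 4.3-fold higher number from compound 2 to compound 4 (0.64 log units; beyond the scatter) and an 8.0-fold higher number from compound 1 to compound 4 (0.90 log units; beyond the scatter) both printed as beyond the scatter, so the four compounds fall into a halogen pair and a pair of hydrogen and methyl, and none goes against this split. No measurement at hand accounts for the split.

As far as these compounds go, whether bromo would join the halogen pair, or whether methoxy or an amine at this carbon would fall with hydrogen and methyl, stays open. Also open, from the compounds shown here alone, is whether the split holds for chloro or fluoro on another carbon of this ring.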